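A few compounds are considered here, and "the series" means these few. Any claim that something is new, unique, unknown or untested is made for them only; others in the source may bear on it.

Compound 1 `CC(=O)Nc1cccc(Cn2cc(-c3ccc4c(N)n[nH]c4c3)ccc2=O)c1` gives 8 nM in an assay for inhibition of MAP kinase-interacting serine/threonine-protein kinase 2 (Homo sapiens), read by luminescence and ADP-Glo, with a stated time of 2 h; on this read-out higher numbers stand for weaker inhibition and lower numbers for stronger inhibition.
Compound 2 `Nc1n[nH]c2cc(-c3ccc(=O)n(Cc4cccc(C(F)(F)F)c4)c3)ccc12` gives 21 nM in this assay.

Among the compounds with values here, of the two numbers recorded, compound 2 stands highest; its nearest neighbour is compound 1, and the one measured step, a 2.6-fold higher number from compound 1 to compound 2 (0.42 log units; beyond the scatter), was modest yet beyond the scatter. The unmeasured compound 3 `Nc1n[nH]c2cc(-c3ccc(=O)n(Cc4ccccc4)c3)ccc12` differs from compound 2 by hydrogen in place of trifluoromethyl on an aromatic carbon: the group sits on an aromatic carbon of a six-membered aromatic ring of carbon only, the same position that carries acetamido in compound 1 and trifluoromethyl in compound 2. Within the data shown here, only that single step bears on the change, and it shows that exchanging one substituent for another at this carbon shifts the result by a modest amount, so removing the substituent altogether is expected to move this assay by no more than a similar modest amount, most likely towards a somewhat higher number. Compound 3 is therefore expected to give about 30 nM, within a range of 10 nM to 90 nM, which corresponds to an estimated 1.4-fold higher number from compound 2 to compound 3 (0.15 log units; within the scatter).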

Compound 3, half-maximal inhibitory concentration: 32 nM
The estimate for compound 3 lay 1.1-fold (0.03 log units) below the measured number; low and high end bracket the measured number.
By their numbers in this assay, from the lowest: compound 1; then compounds 2 and 3 (each within the scatter of the next).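

Compound 3 shows what this aromatic carbon does with no substituent at all, and in this assay the exchange of trifluoromethyl for hydrogen cannot be told apart from no change (a 1.5-fold higher number from compound 2 to compound 3 (0.18 log units; within the scatter)). Hydrogen in place of acetamido, by contrast, gives a clear if modest loss (a 4.0-fold higher number from compound 1 to compound 3 (0.60 log units; beyond the scatter)), so among these three compounds only acetamido separates from the others, and compound 1 keeps the lowest number, while trifluoromethyl brings no gain that can be read over plain hydrogen. Why acetamido stands apart cannot be said, as nothing measured here beyond these numbers bears on the result.

The compounds shown leave open whether the advantage belongs to acetamido specifically or would also appear with an amine, a carboxylic acid, a methoxy group or a longer amide chain at this carbon. They also leave open whether acetamido would give the same result on another carbon of the same ring, and whether the pattern holds in any read-out other than this one.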